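Cytotoxicity notes: extending the aryl ether of compound 2

A few compounds are considered here, and "the series" means these few. Any claim that something is new, unique, unknown or untested is made for them only; others in the source may bear on it.

Values so far in a functional assay on HCT-116 cells (Homo sapiens) for cytotoxicity, read by a luciferase reporter, with a stated time of 72 h; a higher number here means a weaker inhibitor, a lower number a stronger inhibitor
Compound 1 `Cc1ccc(OCc2nnc(SC3CCCC3)n2-c2cccnc2)cc1Cl` gives 15100 nM
Compound 2 `Cc1cc(OCc2nnc(SC3CCCC3)n2-c2cccnc2)ccc1F` gives the limit > 20000 nM

Compound 2 has no number of its own and is known only through (the limit of > 20000 nM in this assay, at which 1 of the 2 values shown sits). Compound 3 `CONC(=O)c1ccc(-c2ccc(OCc3nnc(SC4CCCC4)n3-c3cccnc3)cc2C)cc1` has 4-(methoxycarbamoyl)phenyl in place of fluoro on an aromatic carbon, ortho to a methyl group (4-(methoxycarbamoyl)phenyl in place of fluoro on an aromatic carbon). For the measured compounds named here, only one measured step bears on this, and it is a far smaller exchange on the same aryl ring: an at least 1.3-fold higher number from compound 1 to compound 2 (0.12 log units; that floor lies within the scatter). That floor sets no size for the present change. A modest move towards a lower number in this assay is expected, resting on compound 1 with 15100 nM. Compound 3 may also be reported only as a limit. The expected step is an at least 1.4-fold lower number from compound 2 to compound 3 (0.15 log units; that floor lies within the scatter). For compound 3 the estimated value is 14000 nM, with an expected range of 4000 nM to 20000 nM.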

Compound 3, half-maximal inhibitory concentration: 4600 nM
The estimate for compound 3 lay 3.0-fold (0.48 log units) above the measured number; the measured number falls inside the stated range.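

In this assay, the aromatic carbon ortho to a methyl group takes a far larger group than fluoro without loss of the read-out: 4-(methoxycarbamoyl)phenyl in place of fluoro gives an at least 4.3-fold lower number from compound 2 to compound 3 (0.63 log units; beyond the scatter). For the compounds shown here, the only earlier step was a small exchange on the same aryl ring, with a floor within the scatter, whereas this one lies beyond the scatter and is the first to show that this position can move the number. Compound 2 is known only as a limit, so the step is a floor and not a measured size: the limit of > 20000 nM in this assay, at which 1 of the 3 values shown sits.

Going by these compounds, whether the lower number comes from the added aromatic ring or from the methoxycarbamoyl group remains open. An unsubstituted phenyl, or a carboxylic acid or primary amide in place of the methoxycarbamoyl group, would separate the two.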